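Swapping Nitrile for Hydroxymethyl at the Weak End

This account rests on a few compounds, and the source may have more. Where it says the series, first, only, none or still open, it means among the compounds named here.

In a functional assay (aorta) for inhibition, with Rattus norvegicus as the target (a higher number here means a weaker inhibitor, a lower number a stronger inhibitor), compound 1 `CCC/N=C(\S)[C@]1(c2cccnc2)CCCC[S+]1[O-]` gives 600 nM. Compound 2 `CC(C)/N=C(\S)[C@]1(c2cccnc2)CCCC[S+]1[O-]` gives 10000 nM, and its isopropyl in place of propyl on a double-bonded nitrogen marks a 17-fold higher number from compound 1 to compound 2 (1.22 log units; beyond the scatter).

Compound 3 `N#C[C@]1(c2cccnc2)CCCC[S+]1[O-]` shows > 30000 nM, which is a limit and not a number. It therefore sits at the weak end of this small set, as the limit of > 30000 nM in this assay, at which 1 of the 3 values shown sits, records.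

Compound 4 `[O-][S+]1CCCC[C@]1(CO)c1cccnc1` carries hydroxymethyl in place of cyano on a saturated ring carbon. For the measured compounds named here, no measured step makes this exact swap. The closest are the steps that put cyano on that carbon in place of the larger group, an at least 50-fold higher number from compound 1 to compound 3 (1.69 log units; beyond the scatter) and an at least 3.0-fold higher number from compound 2 to compound 3 (0.47 log units; beyond the scatter). Both are beyond the scatter and both lead to a weaker result. Compound 4 also lacks that larger group, so it is expected to stay weak, as the result for compound 3 at > 30000 nM suggests.

The expected step is a number no higher from compound 3 to compound 4 (the limit leaves the size open), with no change beyond the scatter. For compound 4 the estimated value is 30000 nM, with an expected range of 10000 nM to 100000 nM.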

Compound 4, concentration for 90% inhibition: > 30000 nM
Compound 4: a limit, no number (the forecaster's own chance of this, stated with the estimate: 80%); the middle value sits exactly at the limit.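

In this assay compound 4 gives > 30000 nM as a limit and not a number. Compound 3 also has only a limit, so the step between these two cannot be read. What is new is that the loss on this saturated ring carbon does not belong to cyano alone, since replacing the larger group with hydroxymethyl, which adds a hydrogen-bond donor that cyano lacks, still gives an at least 50-fold higher number from compound 1 to compound 4 (1.69 log units; beyond the scatter) and an at least 3.0-fold higher number from compound 2 to compound 4 (0.47 log units; beyond the scatter) in this comparison. Two different small groups now share the weak end of the set: the limit of > 30000 nM in this assay, at which 2 of the 4 values shown sit.

Whether hydroxymethyl and cyano differ at all stays hidden behind that limit. Also open, on these data alone, is whether an amine, a carboxylic acid or a longer chain on this carbon would give a readable value, and which part of the larger group in compound 1 matters most.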